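The source may report more compounds than this note shows. Statements on the series, on what has been measured and on what is new or still open speak of the compounds shown alone.

Measured so far in an ADME assay on NCM460 cells (Homo sapiens) for cytotoxicity, read by CCK-8 assay, with a stated time of 48 h; a lower number here means a stronger inhibitor, a higher number a weaker inhibitor:
- Compound 1 `COc1ccc(/C=C\c2cc(OC)c(OC)c(OC)c2)cc1OCc1ccc(CNC(C)(C)C(=O)O)cc1`: > 50000 nM, a limit of the assay
- Compound 2 `COc1ccc(/C=C\c2cc(OC)c(OC)c(OC)c2)cc1OCc1ccc(CN2CCCC[C@H]2C(=O)O)cc1`: > 50000 nM, a limit of the assay
- Compound 3 `COc1ccc(/C=C\c2cc(OC)c(OC)c(OC)c2)cc1OCc1ccc(CNCCN(C)C)cc1`: 35000 nM

Among the measured compounds shown here, compound 3 carries the only actual number of the three, and the rest of the record is the limit of > 50000 nM in this assay, at which 2 of the 3 values shown sit. Compound 4 `COc1ccc(/C=C\c2cc(OC)c(OC)c(OC)c2)cc1OCc1ccc(CN[C@H](C(=O)O)[C@@H](C)O)cc1` departs from compound 3 at a single place: 1-carboxy-2-hydroxypropyl in place of 2-(dimethylamino)ethyl on an amine nitrogen. In words, 1-carboxy-2-hydroxypropyl stands in place of 2-(dimethylamino)ethyl on an amine nitrogen.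

For the measured compounds named here, two measured steps bear on this change, since compound 1 and compound 2 both carry a carboxy group where compound 3 has the 2-(dimethylamino)ethyl chain. They are an at least 1.4-fold lower number from compound 1 to compound 3 (0.15 log units; that floor lies within the scatter) and an at least 1.4-fold lower number from compound 2 to compound 3 (0.15 log units; that floor lies within the scatter). Each gives only a floor, so neither true size can be read.

Compound 4 gains a carboxy group and so resembles compound 1 more than compound 3. A small rise in the number is therefore expected, not clearly beyond the scatter, and a reading at the limit is the likeliest outcome. The expected move is a 1.4-fold higher number from compound 3 to compound 4 (0.15 log units; within the scatter). Compound 4 is estimated at 50000 nM, with an expected range of 30000 nM to 90000 nM.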

Compound 4, half-maximal inhibitory concentration: > 50000 nM
Compound 4: a limit, no number; the forecaster's own chance of this, stated with the estimate: 70%; the middle value sits exactly at the limit.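

In this assay, 1-carboxy-2-hydroxypropyl in place of 2-(dimethylamino)ethyl on the amine nitrogen gives an at least 1.4-fold higher number from compound 3 to compound 4 (0.15 log units; that floor lies within the scatter) and so leaves the true size of the step unknown. Compound 4 gives a limit and not a number, and its steps from compound 1 and compound 2 cannot be read, so nothing can be said about how its side chain, with its 2 defined stereocentres, compares with theirs. Among the compounds shown here, all three compounds with a carboxy group on this side chain now share one limit, and compound 3, which has no carboxy group there, remains the only one with an actual number, so the earlier picture now extends to an open chain bearing a hydroxy group, with a single compound on the other side of the comparison: the limit of > 50000 nM in this assay, at which 3 of the 4 values shown sit.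

As far as these compounds go, whether the number of compound 3 belongs to the dimethylamino group itself stays open, as a longer chain ending in dimethylamino or a morpholine ring on the same amine nitrogen would be needed to test it. An ester of the carboxylic acid would likewise show whether the free acid goes with the limit at all.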